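The source may report more compounds than this note shows. Statements on the series, on what has been measured and on what is new or still open speak of the compounds shown alone.

Measured compounds in the series:
compound 1 `O=C1O/C(=C\Cn2cc(-c3ccc(Br)cc3)nn2)C(OCc2ccccc2)=C1OCc1ccccc1`; in a functional assay on CFPAC-1 cells (Homo sapiens) for antiproliferative activity, read by MTT assay, with a stated time of 72 h (on this read-out lower numbers stand for stronger inhibition and higher numbers for weaker inhibition), compound 1 gives > 100000 nM, a limit of the assay and not a number.
compound 2 `O=C1O[C@H]([C@@H](O)Cn2cc(-c3cc(C(F)(F)F)cc(C(F)(F)F)c3)nn2)C(OCc2ccccc2)=C1OCc1ccccc1`; in this assay compound 2 gives 66500 nM.

Compound 1 stands at the limit: the limit of > 100000 nM in this assay, at which 1 of the 2 values shown sits. Among the measured compounds shown here, nothing more than this limit is known for compound 1, so no measured step starts from a number here. Compound 3 `Cc1ccc(-c2cn(C/C=C3\OC(=O)C(OCc4ccccc4)=C3OCc3ccccc3)nn2)cc1` differs from compound 1 by methyl in place of bromo on an aromatic carbon; the rest of the shared core is unchanged. For the measured compounds named here, no step between measured compounds is available to calibrate this exchange. Given that compound 1 sits at the limit, no step beyond the usual scatter is expected in this assay, in either direction. Compound 3 is therefore expected to give about 150000 nM, with a range from 50000 nM to 500000 nM, and most probably only a limit will be reported. The expected step is a step that the limit leaves unreadable from compound 1 to compound 3, within the scatter.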

Compound 3, half-maximal inhibitory concentration: > 100000 nM
Compound 3 ended at the assay's limit; the forecaster's own chance of this, stated with the estimate: 70%; the middle value lies beyond the limit too.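

No new step can be read between compound 1 and compound 3, as both results in this assay are limits and not numbers: the limit of > 100000 nM in this assay, at which 2 of the 3 values shown sit.

The compounds shown leave open what methyl in place of bromo on an aromatic carbon does to a value within the measurable range of this assay.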